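The compounds below may be only part of what the source reports. "The series", "measured", "known", "first", "only" and "open" are said of these compounds alone.

Measured compounds: compound 1 `COc1ncc(-c2ccccc2)cc1[C@@H](c1ccccc1)[C@@](O)(CCN(C)C)c1ccccc1` with 11.9 ug/mL; compound 2 `COc1nc(-c2cccc(Cl)c2)ccc1[C@@H](c1ccccc1)[C@@](O)(CCN(C)C)c1cccc2ccccc12` with "nd" (no result reported); compound 3 `COc1ncc(-c2ccccc2)cc1[C@@H](c1ccccc1)[C@@](O)(CCN(C)C)c1cccc(F)c1F` with 28.1 ug/mL.

In a toxicity assay on HeLa cells (Homo sapiens) for cytotoxicity (on this read-out higher numbers stand for lower toxicity in this test and lower numbers for higher toxicity in this test), compound 1 gives 11.9 ug/mL and compound 3 gives 28.1 ug/mL, while compound 2 stands without any number. Compound 4 `COc1nc(-c2ccc(F)cc2)ccc1[C@@H](c1ccccc1)[C@@](O)(CCN(C)C)c1cccc2ccccc12` differs from compound 2 by 4-fluorophenyl in place of 3-chlorophenyl on an aromatic carbon. Within the data shown here, the only measured step, a 2.4-fold higher number from compound 1 to compound 3 (0.37 log units; beyond the scatter), concerns a different site, the saturated chain carbon bound to an oxygen, so it does not bear directly on this change, and compound 2 itself offers no starting number. With no guide, no step beyond the scatter is assumed, and compound 4 is placed near the measured values of compounds 1 and 3. Compound 4 is expected to give about 15 ug/mL, within 5 ug/mL to 45 ug/mL.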

Compound 4, half-maximal cytotoxic concentration: > 64 ug/mL
Compound 4 ended at the assay's limit; the forecaster's own chance of this, stated with the estimate: 20%; middle value at least 4.2-fold (0.63 log units) from the limit.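

For compound 4, this assay gives > 64 ug/mL, which is a limit of the assay and not a number. Among these compounds, compound 2 has no reported result, and no step to compound 4 can be read. The compounds shown leave open what 4-fluorophenyl in place of 3-chlorophenyl does on this read-out.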